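A methyl on the amine nitrogen of compound 2

The source may hold more compounds than are shown below. What is called first, only, known or untested is meant among the compounds shown, and "the series" means these compounds.

In a functional assay on SK-BR-3 cells (Homo sapiens) for antiproliferative activity (on this read-out lower numbers stand for stronger inhibition and higher numbers for weaker inhibition), compound 1 `CC(C)=CCc1cc(C(=O)Nc2cc3ccc(OCC4CCCN(C)C4)c(C)c3oc2=O)ccc1O` gives 1300 nM and compound 2 `CCNCCCOc1ccc2cc(NC(=O)c3ccc(O)c(CC=C(C)C)c3)c(=O)oc2c1C` gives 720 nM. Among the compounds with values here, compound 2 therefore has only one neighbour on this scale, and the two numbers lie within the usual scatter of each other. Compound 3 `CCN(C)CCCOc1ccc2cc(NC(=O)c3ccc(O)c(CC=C(C)C)c3)c(=O)oc2c1C` differs from compound 2 in one place, with methyl in place of hydrogen on an amine nitrogen. This exact change has not been measured. Within the data shown here, the one measured step bears on it only loosely: a 1.8-fold lower number from compound 1 to compound 2 (0.26 log units; within the scatter). There, 2-(ethylamino)ethyl stands in place of 1-methylpiperidin-3-yl, which also carries a methyl on its amine nitrogen. With so little evidence, no step beyond the scatter is expected in this assay. The expected step is a 1.1-fold higher number from compound 2 to compound 3 (0.05 log units; within the scatter). For compound 3 the estimated value is 800 nM, with an expected range of 300 nM to 2000 nM.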

Compound 3, half-maximal inhibitory concentration: 730 nM
The estimate for compound 3 lay 1.1-fold (0.04 log units) above the measured number; measured number inside the range.
By their numbers in this assay, from the lowest: compounds 2, 3 and 1 (each within the scatter of the next).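

In this assay, methyl in place of hydrogen on the amine nitrogen gives a 1.0-fold higher number from compound 2 to compound 3 (0.01 log units; within the scatter) and so stays within the scatter, which means that ethylamino and ethyl(methyl)amino cannot be told apart at this position. Putting 2-(ethyl(methyl)amino)ethyl in place of 1-methylpiperidin-3-yl gives a 1.8-fold lower number from compound 1 to compound 3 (0.25 log units; within the scatter) and also stays within the scatter, so an open chain and a ring both carrying a methyl on the amine nitrogen cannot be told apart either. No measurement is available to explain these results.

On these data alone, it remains open whether a bulkier group on this nitrogen, such as isopropyl or benzyl, would also leave the number within the scatter. Also open, as far as these compounds go, is what a primary amine, an amide or a carboxylic acid at the end of the chain would do.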